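The source may report more compounds than this note shows. Statements on the series, on what has been measured and on what is new or still open speak of the compounds shown alone.

Among the measured compounds shown here, in a functional assay on DU-145 cells (Homo sapiens) for inhibition, read by trypan blue exclusion, with a stated time of 72 h (a lower number here means a stronger inhibitor, a higher number a weaker inhibitor), compound 2 `Cn1c(=O)c(S(=O)(=O)c2ccc(F)cc2)cc2cnc(Nc3ccc4[nH]ccc4c3)nc21` gives 300 nM, the lower of the two numbers measured so far. Compound 1 `Cn1c(=O)c(S(=O)(=O)Cc2ccc(F)cc2)cc2cnc(Nc3ccc4[nH]ccc4c3)nc21` gives 30000 nM in this assay, so the change is a 100-fold lower number from compound 1 to compound 2 (2.00 log units; beyond the scatter). Compound 3 `Cn1c(=O)c(S(=O)(=O)c2ccc(F)cc2N)cc2cnc(Nc3ccc4[nH]ccc4c3)nc21` has not yet been measured; it differs from compound 2 by amino in place of hydrogen on an aromatic carbon. For the measured compounds named here, no measured step puts an amino group in place of a hydrogen, and the single large step seen concerns a different change, so it offers no direct guide. Compound 3 is therefore expected to give 300 nM in this assay, within a range of 100 nM to 1000 nM. The step of no change at the digits printed from compound 2 to compound 3 (within the scatter) is expected to stay within the usual scatter.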

Compound 3, half-maximal inhibitory concentration: 3000 nM
Estimate against measurement, compound 3: 10-fold (1.00 log units) below; measured number above the stated range.
By their numbers in this assay, from the lowest: compound 2; then compound 3; then compound 1.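

In this assay, the ring carbon ortho to a large group and meta to the fluoro group proves sensitive to a small addition: amino in place of hydrogen gives a 10-fold higher number from compound 2 to compound 3 (1.00 log units; beyond the scatter), a weaker inhibitor. The 2-amino-4-fluorophenyl group still keeps an edge over 4-fluorobenzyl on the sulfonyl sulfur, with a 10-fold lower number from compound 1 to compound 3 (1.00 log units; beyond the scatter). No measurement at hand explains why the amino group weakens compound 2.

As far as these compounds go, whether a hydroxyl, a methyl or a chlorine on that same carbon would weaken compound 2 as much remains open. So does the effect of an amino group on another carbon of that ring.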